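The compounds below may be only part of what the source reports. "The series", "measured", "known", "first", "only" and "open" are said of these compounds alone.

Of the compounds shown here, three have been tested in a functional assay on cells (Lymphocyte, Homo sapiens), read by trypan blue exclusion, with a stated time of 16 h, tested at 0.1 uM; on this read-out higher numbers stand for a stronger effect at the one concentration tested and lower numbers for a weaker effect. Compound 1 `CCCCCCCCCCCCCCCCc1c(C)c(N(C)C)nc(C)c1O` gives 11%, and compound 2 `CCCCCCCCCCCCCCCCCCCc1c(C)c(N(C)C)nc(C)c1O` gives 8%; the two differ by hydrogen in place of propyl on a saturated chain carbon, ten or more bonds along the chain from an aromatic carbon, and the step of a number 3 percentage points higher from compound 2 to compound 1 (within the scatter) lies within the scatter. Compound 3 `CCCCCCCCCCCCCCCCCCCc1nc(N(C)C)c(C)c(C)c1O` has the same atoms as compound 2 joined differently; the difference between the two cores is not broken down here. In this assay compound 3 gives 4%, within the scatter of the other two. Compound 4 `CCCCCCCCCCCCCCCCc1nc(N(C)C)c(C)c(C)c1O`, not yet measured, differs from compound 3 by hydrogen in place of propyl on a saturated chain carbon, ten or more bonds along the chain from an aromatic carbon, the same change as made from compound 2 to compound 1. That earlier step a number 3 percentage points higher from compound 2 to compound 1 (within the scatter) stayed within the scatter. The step to compound 4 is expected to be similarly small, a number 2 percentage points higher from compound 3 to compound 4 (within the scatter). Compound 4 is therefore estimated at 6%, between 0% and 14%.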

Compound 4, a percentage reported as activity, at one concentration (the size of the read-out at that concentration, not a potency): 29%
For compound 4 the middle estimate is 23 percentage points below the measured one, outside the stated range (above it).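

In this assay, hydrogen in place of propyl on the chain gives a number 25 percentage points higher from compound 3 to compound 4 (beyond the scatter). The same change does not carry over from one core to the other with the same size: the same change on two cores in this assay, a number 3 percentage points higher (within the scatter) from compound 2 to compound 1 and a number 25 percentage points higher (beyond the scatter) from compound 3 to compound 4, 22 percentage points apart, beyond the scatter of two such steps So in these two pairs the effect of shortening the chain depends on the core it is made on, but two pairs give no general rule for other cores and do not explain why the steps differ.

On these data alone, it remains open whether a shorter chain, or a chain carrying a carboxylic acid, would behave on each core as these pairs do. As far as these compounds go, a read-out at a single concentration also shows the effect of compound 4 at that concentration only, and whether it would be stronger or weaker at other concentrations remains open.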